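A few compounds are considered here, and "the series" means these few. Any claim that something is new, unique, unknown or untested is made for them only; others in the source may bear on it.

Working notes on an ADME assay on BHK-21 cells (Mesocricetus auratus) for cytotoxicity, read by MTT assay; a higher number here means that more compound is tolerated, a lower number that less compound is tolerated. Going by the values given here, compound 1 `COc1ccc(-c2nc3cc(/C(C)=N/NC(N)=S)ccc3[nH]2)cc1` gives 13000 nM, the lowest of the two numbers so far. Compound 2 `COc1ccc(-c2nc3cc(/C(C)=N/NC(N)=S)ccc3[nH]2)c(OC)c1` gives 28000 nM. The next compound to be read is compound 3 `C/C(=N\NC(N)=S)c1ccc2[nH]c(-c3ccoc3)nc2c1`, with furan-3-yl in place of 4-methoxyphenyl on an aromatic carbon of the five-membered aromatic ring with 2 nitrogen: furan-3-yl in place of 4-methoxyphenyl on an aromatic carbon. Among the compounds with values here, only one measured step bears on this change: a 2.2-fold higher number from compound 1 to compound 2 (0.33 log units; beyond the scatter), a modest rise with methoxy in place of hydrogen on the 4-methoxyphenyl group. Within the data shown here, no measured step replaces that whole group, so the direction is uncertain. With that single step as a guide, a similarly modest rise is expected, and the estimated step is a 1.4-fold higher number from compound 1 to compound 3 (0.14 log units; within the scatter). For compound 3 the estimate is 18000 nM, with an expected range of 7000 nM to 45000 nM.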

Compound 3, half-maximal cytotoxic concentration: > 100000 nM
Compound 3 was reported as a limit; the forecaster's own chance of this, stated with the estimate: 10%; middle value at least 5.5-fold (0.74 log units) away from the limit.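

In this assay, exchanging the whole 4-methoxyphenyl group for furan-3-yl at this place, between two ring nitrogen atoms, gives an at least 7.6-fold higher number from compound 1 to compound 3 (0.88 log units; beyond the scatter), whereas added methoxy on that group gave only a 2.2-fold higher number from compound 1 to compound 2 (0.33 log units; beyond the scatter). Compound 3 is reported as a limit, > 100000 nM. The aromatic group on this carbon therefore has a clear effect on the read-out, not just its methoxy substitution, but the size of the step remains a bound: the limit of > 100000 nM in this assay, at which 1 of the 3 values shown sits.

The one step changes both the ring and the methoxy group, so the compounds shown do not tell whether the rise follows from gaining furan-3-yl or from losing the 4-methoxyphenyl group. As far as these compounds go, how an unsubstituted phenyl, a thiophen-3-yl or a furan-2-yl group would read at this place stays open.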